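Two Hydroxyls in Place of Two Chlorines: Compound 4

The source may report more compounds than this note shows. Statements on the series, on what has been measured and on what is new or still open speak of the compounds shown alone.

Compound 1 `CN(C)CCn1cnnc1-c1cc(Oc2ccc(NC(=O)N/N=C/c3ccc(Cl)cc3Cl)cc2F)ccn1` is measured in a functional assay on U-87MG ATCC cells (Homo sapiens) for cytotoxicity, read by MTT assay, with a stated time of 72 h (a higher number here means a weaker inhibitor, a lower number a stronger inhibitor), where compound 1 gives 2330 nM. Of the two plain numbers shown, this is the lowest; compound 2 `CN(C)CCn1cnnc1-c1cc(Oc2ccc(NC(=O)N/N=C/c3ccccc3O[N+](=O)[O-])cc2F)ccn1` gives 7150 nM, and the step of a 3.1-fold higher number from compound 1 to compound 2 (0.49 log units; beyond the scatter) puts a 2-(nitrooxy)phenyl in place of the 2,4-dichlorophenyl. Compound 3 `CN(C)CCn1cnnc1-c1cc(Oc2ccc(NC(=O)N/N=C/c3ccc(O)c(O)c3)cc2F)ccn1` gives > 100000 nM, which is a limit of the assay rather than a number. The step of an at least 42-fold higher number from compound 1 to compound 3 (1.63 log units; beyond the scatter) shows how strongly a 3,4-dihydroxyphenyl weakens inhibition, and the step of an at least 13-fold higher number from compound 2 to compound 3 (1.14 log units; beyond the scatter) points the same way.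

Compound 4 `CN(C)CCn1cnnc1-c1cc(Oc2ccc(NC(=O)N/N=C/c3ccc(O)cc3O)cc2F)ccn1` differs from compound 1 as follows: 2,4-dihydroxyphenyl in place of 2,4-dichlorophenyl on a carbon with a double bond to nitrogen. This change resembles the one measured as an at least 42-fold higher number from compound 1 to compound 3 (1.63 log units; beyond the scatter), which also placed a dihydroxyphenyl on that carbon, and that step was large, so a large weakening is expected for compound 4 as well, possibly again reaching a limit. Compound 4 is therefore estimated at 60000 nM, with a range from 15000 nM to 200000 nM, an expected step of a 26-fold higher number from compound 1 to compound 4 (1.41 log units; beyond the scatter).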

Compound 4, half-maximal inhibitory concentration: 15400 nM
For compound 4 the middle estimate is 3.9-fold (0.59 log units) above the measured one; the range from low to high includes it.
By their numbers in this assay, from the lowest: compound 1; then compound 2; then compound 4. At a limit, above all of these: compound 3.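

Moving the hydroxyls matters on this carbon with a double bond to nitrogen: the step of an at least 6.4-fold lower number from compound 3 to compound 4 (0.81 log units; beyond the scatter) exchanges 3,4-dihydroxyphenyl for 2,4-dihydroxyphenyl, so having two hydroxyls does not by itself decide the result. Compound 3 gives only a limit, not a number, so that step has a known lower bound but no known full size: the limit of > 100000 nM in this assay, at which 1 of the 4 values shown sits.

Hydroxyls in place of chlorines also cost less here than compound 3 suggested, with a 6.6-fold higher number from compound 1 to compound 4 (0.82 log units; beyond the scatter) counted as modest, and a 2.2-fold higher number from compound 2 to compound 4 (0.33 log units; beyond the scatter) is also modest, though still beyond the scatter.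

From the compounds shown here alone, it remains open whether a phenyl with a single hydroxyl, a methoxy group or an amine would fall nearer compound 1 or compound 4 in this assay. The compounds shown also do not tell why the arrangement of the hydroxyls changes the result.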